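Sulfonamide ring swap: chlorophenyl to naphthyl

The source may hold more compounds than are shown below. What is called first, only, known or untested is meant among the compounds shown, and "the series" means these compounds.

Measured so far in an assay on MDA-MB-231 cells for binding affinity to C-X-C chemokine receptor type 4 (Homo sapiens), read by fluorescence and microscopy, with stated times of 10 min and 30 min; on this read-out higher numbers stand for an effect only at larger amounts of compound and lower numbers for an effect already at smaller amounts:
compound 1 `Cc1ccc(S(=O)(=O)NCc2ccc(CNC(=O)c3ccc(F)cn3)cc2)cc1` gives 1000 nM.
compound 2 `O=C(NCc1ccc(CNS(=O)(=O)c2ccc(Cl)cc2)cc1)c1ccc(F)cc1` gives 100 nM.
compound 3 `O=C(NCc1ccc(CNS(=O)(=O)c2ccc(F)cc2)cc1)c1ccc(F)cc1` gives 1 nM.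

Compound 2 stands second highest of these three numbers: compound 1 sits above it, compound 3 sits far below it. Within the data shown here, the only single-point step is a 100-fold lower number from compound 2 to compound 3 (2.00 log units; beyond the scatter), which alters the substituent of the sulfonamide ring while keeping the ring itself. Compound 4 `O=C(NCc1ccc(CNS(=O)(=O)c2cccc3ccccc23)cc1)c1ccc(F)cc1` instead changes the whole ring: naphthalen-1-yl in place of 4-chlorophenyl on a sulfonyl sulfur. Among the measured compounds shown here, no measured pair shows such an exchange, so the step from compound 2 to compound 3 bears on it only as a sign that this part of the molecule moves the read-out strongly. In this assay compound 4 is expected near compound 2, at 100 nM (range 20 nM to 1000 nM), the expected step being no change at the digits printed from compound 2 to compound 4 (within the scatter).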

Compound 4, effective concentration (reported as EC, without a stated level of effect): 1000 nM
The estimate for compound 4 lay 10-fold (1.00 log units) below the measured number; low and high end bracket the measured number.
By their numbers in this assay, from the lowest: compound 3; then compound 2; then compounds 1 and 4 (each within the scatter of the next).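

In this assay, exchanging the whole ring on the sulfonyl sulfur also moves the read-out, in the direction of weaker binding: the change is modest against the 4-chlorophenyl ring (a 10-fold higher number from compound 2 to compound 4 (1.00 log units; beyond the scatter)) and large against the 4-fluorophenyl ring (a 1000-fold higher number from compound 3 to compound 4 (3.00 log units; beyond the scatter)). This place therefore responds to the identity of the ring itself, not only to its substituent, and naphthalen-1-yl ranks behind both halogenated phenyl rings. Nothing on hand accounts for this shift. Still open, from the compounds shown here alone, is how a thiophene ring or a methoxy-bearing phenyl ring would fare on the sulfonyl sulfur.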